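Replacing a Hydroxymethyl With an Ester on the Shared Core

The source may hold more compounds than are shown below. What is called first, only, known or untested is meant among the compounds shown, and "the series" means these compounds.

Three compounds share one core and differ only in the group on the six-membered aromatic ring with 1 nitrogen. Compound 1 `Cc1cccc(-c2nc3ccccc3[nH]2)n1` carries a methyl there, compound 2 `CCc1cccc(-c2nc3ccccc3[nH]2)n1` an ethyl, and compound 3 `OCc1cccc(-c2nc3ccccc3[nH]2)n1` a hydroxymethyl. In a functional assay on the whole organism with Rattus norvegicus as the target, read by paw edema, with a stated time of 3 h, at a dose of 100 mg/kg by the oral route (a higher number here means more inhibition at the dose given (going by the name of the read-out), a lower number less inhibition), compound 1 gives 44% and compound 2 gives 41%, a step of a number 3 percentage points lower from compound 1 to compound 2 (within the scatter). Compound 3 gives -13%, the lowest of the three numbers: the step of a number 54 percentage points lower from compound 2 to compound 3 (beyond the scatter) and the step of a number 57 percentage points lower from compound 1 to compound 3 (beyond the scatter) both set it far below the two alkyl compounds.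

Compound 4 `CCOC(=O)c1cccc(-c2nc3ccccc3[nH]2)n1` differs from compound 3 by ethoxycarbonyl in place of hydroxymethyl on an aromatic carbon. Among the compounds with values here, no measured step involves an ethoxycarbonyl group, so only the two large falls from the alkyl compounds to compound 3 bear on this change, and they show no more than that the hydroxymethyl compound sits far below the methyl and ethyl compounds. Whether the ester lands nearer the alkyl compounds or nearer compound 3 the data do not show, so the expectation is a rise with wide uncertainty. Compound 4 is therefore expected to give a step of a number 33 percentage points higher from compound 3 to compound 4 (beyond the scatter). For compound 4 in this assay the estimated value is 20%, with a range from -15% to 45%.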

Compound 4, a percentage reported as inhibition, in the whole organism at one dose (the size of the read-out at that dose, not a potency): 31%
The estimate for compound 4 lay 11 percentage points below the measured number; low and high end bracket the measured number.
By their numbers in this assay, from the lowest: compound 3; then compounds 4, 2 and 1 (each within the scatter of the next, the first and the last beyond it).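

In this assay this place on the six-membered aromatic ring with 1 nitrogen accepts a group larger than methyl or ethyl, and the change to ethoxycarbonyl gives a number 44 percentage points higher from compound 3 to compound 4 (beyond the scatter) and so shows that the low number of compound 3 does not extend to every oxygen-bearing group there. Set against the alkyl compounds, the ester gives a number 10 percentage points lower from compound 2 to compound 4 (within the scatter) and a number 13 percentage points lower from compound 1 to compound 4 (beyond the scatter) so that it can be told apart only from the methyl compound, and only by a modest margin. Nothing at hand gives a reason for the wide gap between the hydroxymethyl and ethoxycarbonyl compounds.

The compounds shown leave open whether the number of compound 4 belongs to the ethyl ester itself or would carry over to a carboxylic acid, a primary amide or a methoxycarbonyl group at this place. They also leave open how an aminomethyl group would stand against the hydroxymethyl of compound 3, and whether the low number of compound 3 would persist with a longer hydroxyalkyl chain.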